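The source may report more compounds than this note shows. Statements on the series, on what has been measured and on what is new or still open speak of the compounds shown alone.

In an ADME assay on BJ cells (Homo sapiens), read by MTT assay, with a stated time of 72 h (on this read-out higher numbers stand for weaker inhibition and lower numbers for stronger inhibition), two compounds have been measured so far:
- compound 1 (`CNc1ncnc2c1c(-c1cccs1)cn2[C@@H]1O[C@H](CO)[C@@H](O)[C@H]1O`) gives > 100000 nM as a limit
- compound 2 (`Cc1ncnc2c1c(-c1ccoc1)cn2[C@@H]1O[C@H](CO)[C@@H](O)[C@H]1O`) gives 89200 nM as a number

Compound 1 stands at > 100000 nM and this reading is a limit of the assay, not a number. Compound 2 gives 89200 nM as the only actual number shown in this assay so far, which leaves it without a numerical comparison.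

Compound 3 (`Cc1ncnc2c1c(-c1cccs1)cn2[C@@H]1O[C@H](CO)[C@@H](O)[C@H]1O`) keeps the core of compound 2 but has thiophen-2-yl in place of furan-3-yl on an aromatic carbon. This ring sits on a five-membered aromatic ring with 1 nitrogen, part of a fused or bridged system of two rings. Among the measured compounds shown here, no measured pair shows what such an exchange does, so any forecast rests on a single anchor. The expectation is therefore for no change beyond the scatter in this assay and for no firm direction. The expected step of a 1.3-fold lower number from compound 2 to compound 3 (0.11 log units; within the scatter) is an estimate that stays within that scatter. For compound 3 the estimated value is 70000 nM with an expected range from 20000 nM to 100000 nM in this assay.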

Compound 3, half-maximal inhibitory concentration: > 100000 nM
Compound 3 was reported as a limit; the forecaster's own chance of this, stated with the estimate: 35%; at least 1.4-fold (0.15 log units) between middle value and limit.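

In this assay, among the compounds shown here, the exchange of furan-3-yl for thiophen-2-yl on this aromatic carbon gives the first step that can be read at this position, an at least 1.1-fold higher number from compound 2 to compound 3 (0.04 log units; that floor lies within the scatter), and only a floor is known for its size. The change therefore shows no firm separation between the two rings here, although the true step could be larger than that floor. With compound 3, the series now rests mostly on one limit of the assay, and the step from compound 1 to compound 3, which exchanges methylamino for methyl, cannot be read: the limit of > 100000 nM in this assay, at which 2 of the 3 values shown sit.

What the compounds shown leave open is how far the number moves with furan-3-yl or thiophen-2-yl replaced on this aromatic carbon by a phenyl ring or a carboxylic acid. They also leave open whether methylamino and methyl differ at all, since a reading for either group with furan-3-yl in place would be needed beside compound 2 to tell.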